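Propylamino to allylamino: one change, one expectation

The source may hold more compounds than are shown below. What is called first, only, known or untested is meant among the compounds shown, and "the series" means these compounds.

Compound 1, `CCCNC(=C\C(=O)/C=C/c1ccc(O)c(OC)c1)/C=C/c1ccc(O)c(OC)c1`: 78%
Compound 2, `CCC(C)NC(=C\C(=O)/C=C/c1ccc(OC(C)=O)c(OC)c1)/C=C/c1ccc(OC(C)=O)c(OC)c1`: 68%

Of the compounds shown here, two have been measured in a functional assay on EA.hy 926 cells (Homo sapiens), read by fluorescence, tested at 1 uM; a higher number here means a stronger effect of the compound at the concentration tested, a lower number a weaker effect. Compound 1 gives 78%, and compound 2 gives 68%. The two numbers lie within the usual scatter of each other, so neither compound can be called the more active; compound 1 simply holds the higher of the two numbers, with compound 2 nearest to it. Compound 3 `C=CCNC(=C\C(=O)/C=C/c1ccc(O)c(OC)c1)/C=C/c1ccc(O)c(OC)c1` has not been measured yet. It differs from compound 1 in a single place: vinyl in place of ethyl on a saturated chain carbon bound to an amine nitrogen. For the measured compounds named here, no pair of measured compounds shows what this change does, so the expectation rests on compound 1 alone. Because compound 1 gives 78% in this assay, compound 3 is expected to land near that number. The step expected from this change is a number 3 percentage points lower from compound 1 to compound 3 (within the scatter), which is nothing beyond the scatter in either direction. Compound 3 is therefore estimated at 75%, with a range from 60% to 88%.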

Compound 3, a percentage reported as activity, at one concentration (the size of the read-out at that concentration, not a potency): 124%
Compound 3: middle estimate off by 49 percentage points, on the low side; measured number above the stated range.
By their numbers in this assay, from the lowest: compounds 2 and 1 (each within the scatter of the next); then compound 3.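

In this assay, propylamino to allylamino gives a number 46 percentage points higher from compound 1 to compound 3 (beyond the scatter), so this place, on a saturated chain carbon bound to an amine nitrogen, is not indifferent to what stands on it. The exchange of ethyl for vinyl keeps the count of two heavy atoms and adds only one double bond outside aromatic rings, yet that single change is enough to move the read-out well beyond the scatter. Nothing measured here accounts for the size of this step.

The compounds shown leave open whether a propargyl group, with a carbon-carbon triple bond, or a longer unsaturated chain such as butenyl would give a similar step. They also leave open whether allylamino would act the same way on a core bearing the acetate esters of compound 2.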